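Amide variation on a shared core, HeLa antiproliferation

The source may hold more compounds than are shown below. What is called first, only, known or untested is meant among the compounds shown, and "the series" means these compounds.

Measured so far in a functional assay on HeLa cells (Homo sapiens) for antiproliferative activity, read by MTT assay, with a stated time of 72 h; a higher number here means a weaker inhibitor, a lower number a stronger inhibitor:
compound 1 `O=C(Nc1ccc(Cl)c(-c2nnc3c(Cl)cccn23)c1)c1ccccc1`: > 100000 nM
compound 2 `O=C(Nc1ccc(Cl)c(-c2nnc3c(Cl)cccn23)c1)c1ccon1`: > 100000 nM
compound 3 `O=C(Nc1ccc(Cl)c(-c2nnc3c(Cl)cccn23)c1)c1ccc(Cl)cc1Cl`: > 100000 nM

Each value given for compound 1, compound 2 and compound 3 is a limit of this assay, not a number. Compound 3 therefore stands where every measured member of the series stands: at the limit, with no reading within range. The steps a step that the two limits leave unreadable from compound 1 to compound 2, a step that the two limits leave unreadable from compound 1 to compound 3 and a step that the two limits leave unreadable from compound 2 to compound 3 are each unreadable, since both ends sit at the same limit (the limit of > 100000 nM in this assay, at which 3 of the 3 values shown sit). Among the measured compounds shown here, no measured step gives a size or a direction for any change on the amide aryl group.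

Compound 4 `O=C(Nc1ccc(Cl)c(-c2nnc3c(Cl)cccn23)c1)c1ccc(F)cc1Cl` is the next member. Its change from compound 3 is fluoro in place of chloro on an aromatic carbon. For the measured compounds named here, no measured step bears on this change in a readable way; the only guidance is that all three measured compounds, including compound 3, remain at the limit. Compound 4 is therefore expected to stay near that limit as well, with a step that the limit leaves unreadable from compound 3 to compound 4 as the estimated step. The estimated value for compound 4 in this assay is 150000 nM, with a range from 40000 nM to 600000 nM, and a limit reading is expected to be the most likely outcome.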

Compound 4, half-maximal inhibitory concentration: > 100000 nM
Compound 4: a limit, no number; the forecaster's own chance of this, stated with the estimate: 80%; the middle value is on the limit's open side.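

In this assay compound 4 reads > 100000 nM as a limit, not a number. Its steps from compound 1, compound 2 and compound 3 cannot be read, with all four compounds at the same limit: the limit of > 100000 nM in this assay, at which 4 of the 4 values shown sit.

The compounds shown leave open whether any amide aryl group on the shared core gives a reading within range.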